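Semicarbazide series in a leukaemia cell growth assay

The source may report more compounds than this note shows. Statements on the series, on what has been measured and on what is new or still open speak of the compounds shown alone.

Measured so far:
compound 1 `COc1cc(NC(C)CCCNC(=O)Nc2cccc(Cl)c2)c2ncccc2c1` — 22000 nM
compound 2 `COc1cc(NC(C)CCCNC(=O)NNC(=O)Nc2ccc(F)cc2)c2ncccc2c1` — 118000 nM

In a functional assay on CCRF-CEM cells (Homo sapiens) for inhibition, read by MTT assay, with a stated time of 72 h (a lower number here means a stronger inhibitor, a higher number a weaker inhibitor), compound 2 gives the highest of the two numbers; the nearest is compound 1, and that gap is a 5.4-fold higher number from compound 1 to compound 2 (0.73 log units; beyond the scatter), a step in which the chain end was changed. Compound 3 `COc1cc(NC(C)CCCNC(=O)NNC(=O)Nc2ccc(C(F)(F)F)cc2)c2ncccc2c1` is not yet measured. It differs from compound 2 by trifluoromethyl in place of fluoro on an aromatic carbon. Among the measured compounds shown here, no measured step concerns this kind of change: the single step in hand alters the carbamoyl linkage, not a substituent on the terminal ring, so it gives no direction for the present case. With nothing to support a shift either way, the expectation for compound 3 is a number close to that of compound 2, the step of a 1.2-fold lower number from compound 2 to compound 3 (0.07 log units; within the scatter) being within the usual scatter. Compound 3 is therefore estimated at 100000 nM, with a range from 40000 nM to 300000 nM.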

Compound 3, half-maximal inhibitory concentration: 18000 nM
Compound 3: middle estimate off by 5.6-fold (0.74 log units), on the high side, and the stated range ends above it.
By their numbers in this assay, from the lowest: compounds 3 and 1 (each within the scatter of the next); then compound 2.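

In this assay, the substituent para to a large group on the terminal ring matters: trifluoromethyl in place of fluoro gives a 6.6-fold lower number from compound 2 to compound 3 (0.82 log units; beyond the scatter). The earlier step altered the chain end itself, whereas this one keeps that chain end fixed and shows that a change on the ring alone can move the number beyond the scatter. Nothing measured for these compounds bears on the reason for this shift.

As far as these compounds go, whether another group at this place, such as chloro, methoxy, an amine or a carboxylic acid, would keep, extend or reverse the shift remains open. Also open, from the compounds shown here alone, is whether the same exchange of fluoro for trifluoromethyl would act in the same way on the shorter chain end of compound 1.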